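Thioether versus sulfone linkers with bromoindolyl or trihydroxyphenyl

A few compounds are considered here, and "the series" means these few. Any claim that something is new, unique, unknown or untested is made for them only; others in the source may bear on it.

Four compounds share a chain with a double bond and a carbonyl bound to a chlorophenyl ring; they differ in the linker to the methylbenzyl group and in the aryl group on the double bond. Compound 1 `Cc1ccc(CS/C(=C/c2c(O)cc(O)cc2O)C(=O)c2ccc(Cl)cc2)cc1` and compound 2 `Cc1ccc(CS/C(=C/c2c[nH]c3ccc(Br)cc23)C(=O)c2ccc(Cl)cc2)cc1` carry a thioether; compound 3 `Cc1ccc(CS(=O)(=O)/C(=C/c2c(O)cc(O)cc2O)C(=O)c2ccc(Cl)cc2)cc1` and compound 4 `Cc1ccc(CS(=O)(=O)/C(=C/c2c[nH]c3ccc(Br)cc23)C(=O)c2ccc(Cl)cc2)cc1` carry a sulfone. How the two cores differ beyond that is not broken down here.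

In a functional assay on DU-145 cells (Homo sapiens) for inhibition, read by trypan blue exclusion, with a stated time of 96 h (on this read-out lower numbers stand for stronger inhibition of growth and higher numbers for weaker inhibition of growth), compound 1 gives 50000 nM. Compound 2 gives 1000 nM. The change from compound 1 to compound 2 is 5-bromo-1H-indol-3-yl in place of 2,4,6-trihydroxyphenyl on a double-bonded chain carbon bound to a double-bonded chain carbon and produced a 50-fold lower number from compound 1 to compound 2 (1.70 log units; beyond the scatter). For compound 3 only a limit is reported, > 100000 nM, at the limit of > 100000 nM in this assay, at which 1 of the 3 values shown sits. Compound 4 has not yet been measured.

The change from compound 3 to compound 4 is the same one, (5-bromo-1H-indol-3-yl in place of 2,4,6-trihydroxyphenyl on a double-bonded chain carbon bound to a double-bonded chain carbon), at the same place. Set beside the earlier step, the step from compound 3 to compound 4 is expected to be of comparable size, an at least 20-fold lower number from compound 3 to compound 4 (1.30 log units; beyond the scatter), resting on compound 1 to compound 2 giving a 50-fold lower number from compound 1 to compound 2 (1.70 log units; beyond the scatter). Since compound 3 is known only as a limit, the starting point is uncertain, and compound 4 is expected to land at about 5000 nM, within 1500 nM to 50000 nM.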

Compound 4, concentration for 50% growth inhibition: 10000 nM
Compound 4: the middle estimate sits 2.0-fold (0.30 log units) below what was measured, and the stated range covers the measured number.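

In this assay, 5-bromo-1H-indol-3-yl in place of 2,4,6-trihydroxyphenyl gives a lower number on the sulfone core as it does on the thioether core, and the new step lies beyond the scatter (an at least 10-fold lower number from compound 3 to compound 4 (1.00 log units; beyond the scatter)). This is agreement in direction across a single pair of cores, so it supports carrying the change between these two cores and sets no rule for any other core in the series. Whether the size of the step carries over as well stays unsettled: the same change on two cores in this assay, a 50-fold lower number (1.70 log units; beyond the scatter) from compound 1 to compound 2 and an at least 10-fold lower number (1.00 log units; beyond the scatter) from compound 3 to compound 4; the limit leaves it open whether they differ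

The size of the step on the sulfone core is only a lower bound, since compound 3 is reported only as a limit and not as a number: the limit of > 100000 nM in this assay, at which 1 of the 4 values shown sits.

The compounds shown leave open which part of the change accounts for the lower number, the bromine or the indole itself, a question that a plain 1H-indol-3-yl group or a phenyl ring with a single hydroxyl would address. They also leave open whether the same change holds with a sulfoxide or an amide as the linker to the methylbenzyl group.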